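Quinone amino-acid series: cytotoxicity notes on a rearranged side chain

The compounds below may be only part of what the source reports. "The series", "measured", "known", "first", "only" and "open" are said of these compounds alone.

Compound 1 `CC1=CCC[C@](C)(CC/C(C)=C/CC2=C(O)C(=O)C=C(N[C@@H](C(=O)O)[C@@H](C)O)C2=O)[C@@H]1C`: > 10 ug/mL
Compound 2 `C=C1[C@H](C)CCC[C@]1(C)CC/C(C)=C/CC1=C(O)C(=O)C=C(N[C@H](C(=O)O)[C@H](C)O)C1=O`: > 10 ug/mL

In an ADME assay on L1210 cells (Mus musculus) for cytotoxicity, with a stated time of 48 h (on this read-out lower numbers stand for stronger inhibition and higher numbers for weaker inhibition), compound 1 gives only a limit, > 10 ug/mL. In this assay compound 2 likewise gives only a limit, > 10 ug/mL. Compound 2 therefore stands at the limit of > 10 ug/mL in this assay, at which 2 of the 2 values shown sit, and no numbered value exists anywhere in the series. Compound 3 `CC1=CCC[C@](C)(CC/C(C)=C/CC2=C(O)C(=O)C=C(N[C@H](C(=O)O)[C@H](C)O)C2=O)[C@@H]1C` differs from compound 2 by a group of 9 heavy atoms (9 carbon; one six-membered non-aromatic ring of carbon only) in place of a group of 9 heavy atoms (9 carbon; one six-membered non-aromatic ring of carbon only), on a saturated chain carbon, two bonds along the chain from a double-bonded chain carbon. Among the measured compounds shown here, no measured pair separates a change of this kind, so no size can be read off. Because compound 2 sits at the limit of > 10 ug/mL in this assay, at which 2 of the 2 values shown sit, the step that the limit leaves unreadable from compound 2 to compound 3 is expected to stay within the scatter, in no particular direction. Compound 3 is estimated at 15 ug/mL in this assay, between 5 ug/mL and 50 ug/mL, most likely again reported as a limit.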

Compound 3, half-maximal inhibitory concentration: > 10 ug/mL
Compound 3: no number, only a limit; the forecaster's own chance of this, stated with the estimate: 80%; the middle value is on the limit's open side.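

Among the compounds shown here, compound 3, like compound 1 and compound 2, gives only a limit in this assay, so no step from either compound to compound 3 can be read. The compounds shown leave open whether the ring exchange or the configuration as drawn changes cytotoxicity at all.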